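This account rests on a few compounds, and the source may have more. Where it says the series, first, only, none or still open, it means among the compounds named here.

Three compounds share the same core and differ only in the group attached to a carbonyl carbon on the side chain. Compound 1 `Cc1cn(C2CC(N=[N+]=[N-])C(COC(=O)OCCCCO)O2)c(=O)[nH]c1=O` carries a 4-hydroxybutoxy group there; in an ADME assay on the whole organism (serum) with Homo sapiens as the target (a higher number here means that the compound lasts longer, a lower number that the compound disappears faster), compound 1 gives 0.5 h. Compound 2 `Cc1cn(C2CC(N=[N+]=[N-])C(COC(=O)OCCCCCCO)O2)c(=O)[nH]c1=O` carries the longer (6-hydroxyhexyl)oxy group, and in this assay compound 2 gives 0.117 h, which is a 4.3-fold lower number from compound 1 to compound 2 (0.63 log units; beyond the scatter). Compound 3 `Cc1cn(C2CC(N=[N+]=[N-])C(COC(=O)NCCCN)O2)c(=O)[nH]c1=O` carries a (3-aminopropyl)amino group on that carbon instead. In this assay compound 3 reaches a limit of the assay, > 48 h, so no true number is known for it. Compound 3 thus stands at the top of everything measured here, as the limit of > 48 h in this assay, at which 1 of the 3 values shown sits, shows, reached by an at least 96-fold higher number from compound 1 to compound 3 (1.98 log units; beyond the scatter) and an at least 410-fold higher number from compound 2 to compound 3 (2.61 log units; beyond the scatter). Compound 4 `Cc1cn(C2CC(N=[N+]=[N-])C(COC(=O)OCCO)O2)c(=O)[nH]c1=O` makes the next change: 2-hydroxyethoxy in place of (3-aminopropyl)amino on a carbonyl carbon. This undoes the kind of change that produced the two large steps toward compound 3 and returns to a hydroxyalkoxy group of the sort found in compound 1 and compound 2. A large drop in this assay is therefore expected, an at least 60-fold lower number from compound 3 to compound 4 (1.77 log units; beyond the scatter). The basis for this is that compound 1 gives 0.5 h and compound 2 gives 0.117 h with related groups. Compound 4 is estimated at 0.8 h, with a likely range from 0.25 h to 3 h.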

Compound 4, half-life: < 0.0167 h
Compound 4: no number, only a limit; the forecaster's own chance of this, stated with the estimate: 5%; middle value at least 47-fold (1.68 log units) from the limit.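

Compound 4 gives no true number, only a limit at the low end of this assay: the limit of < 0.0167 h in this assay, at which 1 of the 4 values shown sits.

Replacing (3-aminopropyl)amino with 2-hydroxyethoxy on this carbonyl carbon gives an at least 2800-fold lower number from compound 3 to compound 4 (3.45 log units; beyond the scatter), so the group here can shift the half-life across the whole range shown. Chain length gives no steady trend among the hydroxy-ended groups: the shortest chain shows an at least 7.0-fold lower number from compound 2 to compound 4 (0.84 log units; beyond the scatter) and an at least 29-fold lower number from compound 1 to compound 4 (1.47 log units; beyond the scatter), yet the longest does not last longest, as the 4-hydroxybutoxy group outlasts both the shorter and the longer chain.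

The compounds shown leave open whether the nitrogen attached to the carbonyl carbon or the amine at the chain end goes with the long half-life. A 3-aminopropoxy group or a (3-hydroxypropyl)amino group on this carbon would separate the two.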